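The source may report more compounds than this note shows. Statements on the series, on what has been measured and on what is new or still open speak of the compounds shown alone.

Working notes on the series. In an assay on isolated protein for inhibition of serine protease 1 (Homo sapiens), tested at 100 uM (on this read-out higher numbers stand for more inhibition at the one concentration tested (going by the name of the read-out) and lower numbers for less inhibition), compound 1 `CC1CCCC(C)N1CCCCCN1C(=O)C(c2ccccc2)Oc2ccccc21` gives 2.8%. Compound 2 `CC1CCCC(C)N1CCCCCN1C(=O)C(c2cccc(C(=N)NO)c2)Oc2ccccc21` gives 21%, and compound 3 `C/N=C(/N)c1cccc(C2Oc3ccccc3N(CCCCCN3C(C)CCCC3C)C2=O)c1` gives 32%, the highest of the three numbers, with compound 2 nearest to it and compound 1 furthest. The steps leading to compound 3 are a number 29.2 percentage points higher from compound 1 to compound 3 (beyond the scatter) and a number 11 percentage points higher from compound 2 to compound 3 (beyond the scatter); the parallel step a number 18.2 percentage points higher from compound 1 to compound 2 (beyond the scatter) shows that placing a group of 4 heavy atoms on the same aromatic carbon raises the read-out in either form, all three steps being modest in size.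

Compound 4 `CC1CCCC(C)N1CCCCCN1C(=O)C(c2cccc(C(=N)NN3CCOCC3)c2)Oc2ccccc21` carries a group of 9 heavy atoms (5 carbon, 3 nitrogen, 1 oxygen; one six-membered non-aromatic ring with 2 hetero atoms) in place of a group of 4 heavy atoms (2 carbon, 2 nitrogen; no ring), on an aromatic carbon. Going by the values given here, no measured step exchanges a group of this size at this position; the only exchange of one group for another on this carbon is the step from compound 2 to compound 3, which moved the number by a modest amount. The step expected here, a number 4 percentage points lower from compound 3 to compound 4 (within the scatter), is accordingly small. Among the compounds with values here, the direction is uncertain, as the larger group entering has no precedent among the measured compounds. Compound 4 is therefore estimated to give about 28% in this assay, within a range from 10% to 50%.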

Compound 4, a percentage reported as inhibition, at one concentration (the size of the read-out at that concentration, not a potency): 58%
For compound 4 the middle estimate is 30 percentage points below the measured one; the whole stated range lies below it.
By their numbers in this assay, from the lowest: compound 1; then compound 2; then compound 3; then compound 4.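

In this assay, the read-out at this aromatic carbon does not level off at the values given by the two groups of 4 heavy atoms: the larger group with its six-membered non-aromatic ring gives a number 26 percentage points higher from compound 3 to compound 4 (beyond the scatter), and morpholin-4-yl in place of hydroxy on the amine nitrogen gives a number 37 percentage points higher from compound 2 to compound 4 (beyond the scatter). Measured against a hydrogen atom on the same carbon, the full group gives a number 55.2 percentage points higher from compound 1 to compound 4 (beyond the scatter), the largest step in the series and well above the steps for either smaller group. The data shown offer no measurement that explains this rise.

Still open, from the compounds shown here alone, is whether the gain depends on the morpholine ring itself or on having any substituent of this size on the amine nitrogen; a piperidine or a dimethylamino group there would separate these two readings. Going by these compounds, each number also comes from one concentration, so the series has no potency ranking yet, and it remains open whether the gain would hold with a shorter chain in place of the five-carbon chain on the core.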